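Hydroxy to methoxy on the trimethoxybenzylidene series

This account rests on a few compounds, and the source may have more. Where it says the series, first, only, none or still open, it means among the compounds named here.

Measured in a functional assay on HeLa cells (Homo sapiens) for antiproliferative activity, read by MTT assay, with a stated time of 48 h; a lower number here means a stronger inhibitor of growth, a higher number a weaker inhibitor of growth:
- Compound 1 `COc1cc(/C=C2\Cc3c(cc(OC)c(OC)c3OC)C2=O)cc(OC)c1OC`: 2370 nM
- Compound 2 `COc1cc(/C=C2\Cc3cc(OC)c(OC)c(OC)c3C2=O)cc(OC)c1OC`: > 10000 nM (a limit)
- Compound 3 `COc1cc2c(cc1O)C(=O)/C(=C/c1cc(OC)c(OC)c(OC)c1)C2`: > 10000 nM (a limit)

Compound 3 stands only at a limit, > 10000 nM, and this is not a number. Among the compounds with values here, the series so far shows (the limit of > 10000 nM in this assay, at which 2 of the 3 values shown sit). Compound 1 alone gives a number, 2370 nM.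

Compound 4 `COc1cc2c(cc1OC)C(=O)/C(=C/c1cc(OC)c(OC)c(OC)c1)C2` is next. It differs from compound 3 by methyl in place of hydrogen on an oxygen on an aromatic ring, which is methyl in place of hydrogen on an oxygen on an aromatic ring, or hydroxy to methoxy. Within the data shown here, no measured pair shows this change, so its size cannot be read directly. In this assay a modest move toward stronger growth inhibition is expected, and compound 4 may well remain at the limit. The expected step is an at least 1.4-fold lower number from compound 3 to compound 4 (0.15 log units; that floor lies within the scatter), an estimate made against a limit. For compound 4 the estimated value is 7000 nM, with an expected range of 2000 nM to 25000 nM.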

Compound 4, concentration for 50% growth inhibition: > 10000 nM
Compound 4 ended at the assay's limit (the forecaster's own chance of this, stated with the estimate: 55%); middle value at least 1.4-fold (0.15 log units) away from the limit.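

In this assay compound 4 sits at a limit, > 10000 nM, and this is not a number. Hydroxy to methoxy on an oxygen on an aromatic ring therefore brings no value into readable range, and the steps to compound 4 from compound 3 and from compound 2 cannot be read, as both ends of each are limits. Within the data shown here, the first readable step is an at least 4.2-fold higher number from compound 1 to compound 4 (0.62 log units; beyond the scatter), with hydrogen in place of methoxy on an aromatic carbon, so the methoxy present in compound 1 is the one difference so far tied to a measured gain.

On these data alone, the true size of the hydroxy to methoxy change stays open, as most of the series gives no number: the limit of > 10000 nM in this assay, at which 3 of the 4 values shown sit. Also open is whether an ethoxy group or an amine at that oxygen-bearing place would give a number at all.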